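This account rests on a few compounds, and the source may have more. Where it says the series, first, only, none or still open, it means among the compounds named here.

Three compounds share one sugar-like core, a six-membered ring carrying several hydroxyl groups, joined through an amine to a benzylic arm. Compound 1 `OC[C@H]1O[C@@H](CNCc2ccccc2)[C@H](O)[C@@H](O)[C@@H]1O` carries an unsubstituted phenyl ring and, in an assay on isolated protein for inhibition of lysosomal alpha-glucosidase (Rattus norvegicus), with stated times of 15 min and 60 min (on this read-out lower numbers stand for stronger inhibition and higher numbers for weaker inhibition), compound 1 gives 1330000 nM. Compound 2 `OC[C@H]1O[C@@H](CNCc2ccc(F)cc2)[C@H](O)[C@@H](O)[C@@H]1O` adds a fluorine to that ring; in this assay compound 2 gives 203000 nM, the lowest number of the three. Compound 3 `O=[N+]([O-])c1cccc(CNC[C@@H]2O[C@H](CO)[C@@H](O)[C@H](O)[C@H]2O)c1` instead adds a nitro group, and in this assay compound 3 gives 714000 nM. The fluoro substitution gave a 6.6-fold lower number from compound 1 to compound 2 (0.82 log units; beyond the scatter), while the nitro substitution gave a 1.9-fold lower number from compound 1 to compound 3 (0.27 log units; within the scatter).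

Compound 4 `OC[C@H]1O[C@@H](CNCc2cccs2)[C@H](O)[C@@H](O)[C@@H]1O` differs from compound 2 by thiophen-2-yl in place of 4-fluorophenyl on a saturated chain carbon bound to an amine nitrogen. Among the measured compounds shown here, no measured step exchanges the whole aromatic ring, so the two steps above only show that small changes on that ring shift the number by modest amounts. Losing the fluorine, which carried the strongest measured effect, is expected to raise the number, giving a 3.0-fold higher number from compound 2 to compound 4 (0.47 log units; beyond the scatter). Compound 4 is therefore estimated at 600000 nM, with a range from 150000 nM to 2000000 nM.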

Compound 4, half-maximal inhibitory concentration: 324000 nM
The estimate for compound 4 lay 1.9-fold (0.27 log units) above the measured number; the measured number falls inside the stated range.
By their numbers in this assay, from the lowest: compounds 2 and 4 (each within the scatter of the next); then compounds 3 and 1 (each within the scatter of the next).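

The whole aromatic ring at this place can be exchanged, not only given a new substituent: thiophen-2-yl in place of 4-fluorophenyl gives a 1.6-fold higher number from compound 2 to compound 4 (0.20 log units; within the scatter). Thiophen-2-yl in place of plain phenyl gives a 4.1-fold lower number from compound 1 to compound 4 (0.61 log units; beyond the scatter), so a five-membered ring with no added substituent lands within the scatter of the fluorinated six-membered ring. Nothing measured here explains why the number shifts with this exchange.

The compounds shown do not separate the role of the sulfur atom from that of the smaller ring, which a furan-2-yl group or a thiophen-3-yl group at the same place could help to do. Also open, on these data alone, is how a six-membered ring containing nitrogen, such as pyridin-2-yl, would compare there.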